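Iodine in Place of Phenyl on a Nucleoside Core

The source may hold more compounds than are shown below. What is called first, only, known or untested is meant among the compounds shown, and "the series" means these compounds.

Compound 2 `COc1ncnc2c1c(-c1ccccc1)cn2[C@@H]1O[C@H](CO)[C@@H](O)[C@H]1O` is one of three nucleosides tested in a functional assay on K562 cells (Homo sapiens), read by MTT assay, with a stated time of 72 h; on this read-out lower numbers stand for stronger inhibition and higher numbers for weaker inhibition. In this assay compound 2 gives > 20000 nM, which is a limit of the assay and not a number. Compound 1 `Cc1ncnc2c1c(I)cn2[C@@H]1O[C@H](CO)[C@@H](O)[C@H]1O` gives > 20000 nM in this assay, also a limit. Compound 3 `CNc1ncnc2c1c(-c1ccccc1)cn2[C@@H]1O[C@H](CO)[C@@H](O)[C@H]1O` gives > 20000 nM in this assay, again a limit. So far, then, (the limit of > 20000 nM in this assay, at which 3 of the 3 values shown sit). Among the measured compounds shown here, the only measured step, a step that the two limits leave unreadable from compound 2 to compound 3, cannot be sized because both ends are limits.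

Compound 4 `COc1ncnc2c1c(I)cn2[C@@H]1O[C@H](CO)[C@@H](O)[C@H]1O` differs from compound 2 by iodo in place of phenyl on an aromatic carbon. For the measured compounds named here, no measured step covers this change directly. Compound 1 already carries the iodo group and gives > 20000 nM in this assay, a limit. Compound 4 is therefore expected to remain at the limit as well. The step that the limit leaves unreadable from compound 2 to compound 4 is accordingly expected to stay within the scatter, with no readable direction. For compound 4 the estimated value in this assay is 40000 nM, within a range from 15000 nM to 150000 nM.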

Compound 4, half-maximal inhibitory concentration: 14800 nM
For compound 4 the middle estimate is 2.7-fold (0.43 log units) above the measured one, outside the stated range (below it).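

In this assay compound 4 is the only compound shown that gives a number and not a limit, so a change at this position can now be partly read. The two changes give an at least 1.3-fold lower number from compound 2 to compound 4 (0.13 log units; that floor lies within the scatter) and an at least 1.3-fold lower number from compound 1 to compound 4 (0.13 log units; that floor lies within the scatter), and as both floors lie within the usual scatter, neither step alone shows a real gain. Iodo with methoxy is the only pairing here that leaves the limit, while phenyl with methoxy in compound 2 and iodo with methyl in compound 1 stay there: the limit of > 20000 nM in this assay, at which 3 of the 4 values shown sit.

The step between the two phenyl compounds, compound 2 and compound 3, cannot be read, with limits at both ends. Open too, from the compounds shown here alone, is whether bromo in place of iodo, or an amine in place of methoxy, would also give a number.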